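N-Methylation of a Dichlorobenzyl Amide at the Substance-P Receptor

The compounds below may be only part of what the source reports. "The series", "measured", "known", "first", "only" and "open" are said of these compounds alone.

Measured compounds:
compound 1 `O=C(CC(c1ccccc1)c1ccccc1)Nc1cc(C(F)(F)F)cc(C(F)(F)F)c1`: 3010 nM
compound 2 `O=C(CC(c1ccccc1)c1ccccc1)NCc1cc(Cl)cc(Cl)c1`: 226 nM

Among the compounds with values here, in an assay on CHO cells for displacement of a labelled ligand from Substance-P receptor (Homo sapiens) (on this read-out lower numbers stand for stronger inhibition and higher numbers for weaker inhibition), compound 2 gives 226 nM, the lower of the two numbers, and its only neighbour, compound 1, gives 3010 nM, a gap that lies outside the usual scatter. Compound 3 `CN(Cc1cc(Cl)cc(Cl)c1)C(=O)CC(c1ccccc1)c1ccccc1` differs from compound 2 by methyl in place of hydrogen on an amide-type nitrogen. Within the data shown here, no measured pair in this assay carries this change, so the expectation rests on the change itself. A modest step toward a lower number is expected, a 2.8-fold lower number from compound 2 to compound 3 (0.45 log units; beyond the scatter), though a step within the scatter cannot be ruled out. Compound 3 is estimated at 80 nM, with a range from 20 nM to 400 nM.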

Compound 3, half-maximal inhibitory concentration: 45 nM
Compound 3: middle estimate off by 1.8-fold (0.25 log units), on the high side; the range from low to high includes it.
By their numbers in this assay, from the lowest: compound 3; then compound 2; then compound 1.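

In this assay, methyl in place of hydrogen on the amide-type nitrogen gives a 5.0-fold lower number from compound 2 to compound 3 (0.70 log units; beyond the scatter). Within the data shown here, compounds 1 and 2 both carry the amide hydrogen, so this is the first sign that the amide hydrogen can be replaced here without a rise in the number, and that this nitrogen can itself shift the number. Nothing shown here accounts for the size or direction of this step. As far as these compounds go, it remains open whether an ethyl group or a longer chain on this nitrogen would lower the number further, and whether methyl would have a similar effect in compound 1.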